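Cytotoxicity of a Cyanophenyl Replacement for Dichlorophenyl

A few compounds are considered here, and "the series" means these few. Any claim that something is new, unique, unknown or untested is made for them only; others in the source may bear on it.

Compound 1, `Cc1cc(C)cc(-c2cc(C)c(Nc3ccnc(Nc4ccc(C#N)cc4)n3)c(C)c2)c1`: 4140 nM
Compound 2, `Cc1cc(-c2cc(Cl)cc(Cl)c2)cc(C)c1Nc1ccnc(Nc2ccc(C#N)cc2)n1`: 4290 nM
Compound 3, `Cc1cc(-c2c(C)cccc2C)cc(C)c1Nc1ccnc(Nc2ccc(C#N)cc2)n1`: 2590 nM

In an ADME assay on MT4 cells (Homo sapiens) for cytotoxicity, read by MTT assay, with a stated time of 4 days (a lower number here means that less compound is tolerated, a higher number that more compound is tolerated), compound 2 gives 4290 nM, the highest of the three numbers, yet both a 1.0-fold higher number from compound 1 to compound 2 (0.02 log units; within the scatter) and a 1.7-fold lower number from compound 2 to compound 3 (0.22 log units; within the scatter) lie within the scatter, so the three compounds sit in one cluster. Compound 4, `Cc1cc(-c2cccc(C#N)c2)cc(C)c1Nc1ccnc(Nc2ccc(C#N)cc2)n1`, has not been measured; its change from compound 2 is 3-cyanophenyl in place of 3,5-dichlorophenyl on an aromatic carbon. The two steps that vary this same aryl group bear on it, and neither moved the number beyond the scatter. Compound 4 is therefore expected to stay close to compound 2, with a 1.1-fold lower number from compound 2 to compound 4 (0.03 log units; within the scatter) as the expected step, none beyond the scatter. The estimate for compound 4 in this assay is 4000 nM, between 2000 nM and 8000 nM.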

Compound 4, half-maximal cytotoxic concentration: 920 nM
Compound 4: middle estimate off by 4.3-fold (0.64 log units), on the high side, outside the stated range (below it).
By their numbers in this assay, from the lowest: compound 4; then compounds 3, 1 and 2 (each within the scatter of the next).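

In this assay this aryl position proves able to move the number: 3-cyanophenyl gives a 4.7-fold lower number from compound 2 to compound 4 (0.67 log units; beyond the scatter) and a 2.8-fold lower number from compound 3 to compound 4 (0.45 log units; beyond the scatter) and also a 4.5-fold lower number from compound 1 to compound 4 (0.65 log units; beyond the scatter) while the three earlier aryl groups stayed within the scatter of one another. Among the compounds shown, compound 4 alone stands apart, and it alone carries a nitrile on this ring. Nothing available explains this change. The compounds leave open whether the lower number follows the nitrile itself or the loss of a second ring substituent, which a plain phenyl ring or a ring with a single chlorine could separate.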